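Swapping the Terminal Phenyl for a Trimethylpyrazole

The source may hold more compounds than are shown below. What is called first, only, known or untested is meant among the compounds shown, and "the series" means these compounds.

Compound 1 `CN(Cc1ccc2nccn2c1)c1nnc(-c2ccc(-c3ccccc3)cc2)o1` gives 3160 nM in an assay on isolated protein for inhibition of tyrosine-protein kinase receptor UFO (Homo sapiens), read by LC-MS (a lower number here means a stronger inhibitor, a higher number a weaker inhibitor), the lowest of the three numbers shown, though compound 2 `CN(Cc1ccc2nccn2c1)c1nnc(-c2ccc(-c3ccccc3C#N)cc2)o1` with 3980 nM and compound 3 `Cc1ncccc1-c1ccc(-c2nnc(N(C)Cc3ccc4nccn4c3)o2)cc1` with 6310 nM both lie within the scatter of it. Compound 4 `Cc1nn(C)c(C)c1-c1ccc(-c2nnc(N(C)Cc3ccc4nccn4c3)o2)cc1` differs from compound 1 by 1,3,5-trimethyl-1H-pyrazol-4-yl in place of phenyl on an aromatic carbon. For the measured compounds named here, the steps that bear on this change are the two that alter the same phenyl: a 1.3-fold higher number from compound 1 to compound 2 (0.10 log units; within the scatter) and a 2.0-fold higher number from compound 1 to compound 3 (0.30 log units; within the scatter), neither of which moved the number beyond the scatter. Compound 4 is therefore expected to show a step of a 1.6-fold higher number from compound 1 to compound 4 (0.20 log units; within the scatter), most likely nothing beyond the scatter or a somewhat higher number. The estimate for compound 4 is 5000 nM, within a range from 1600 nM to 16000 nM.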

Compound 4, half-maximal inhibitory concentration: 1260 nM
Compound 4: middle estimate off by 4.0-fold (0.60 log units), on the high side; measured number outside the range, below it.
By their numbers in this assay, from the lowest: compound 4; then compounds 1, 2 and 3 (each within the scatter of the next).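

In this assay, this position proves able to move the number beyond the scatter: 1,3,5-trimethyl-1H-pyrazol-4-yl gives a 2.5-fold lower number from compound 1 to compound 4 (0.40 log units; beyond the scatter), which neither earlier change to the phenyl did. The same group also separates from the other two replacements, with a 3.2-fold lower number from compound 2 to compound 4 (0.50 log units; beyond the scatter) and a 5.0-fold lower number from compound 3 to compound 4 (0.70 log units; beyond the scatter). Nothing available explains this step.

The compounds shown do not separate the contribution of the five-membered aromatic ring from that of its methyl groups. Also open, on these data alone, is how an unsubstituted 1H-pyrazol-4-yl, or a pyrazole carrying a morpholine or a carboxylic acid, would behave here.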